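Removing One Fluoro From a Difluorophenyl Agonist

This account rests on a few compounds, and the source may have more. Where it says the series, first, only, none or still open, it means among the compounds named here.

Of the compounds shown here, three sharing one core have been tested in an assay on isolated protein for agonist activity at Free fatty acid receptor 1 (Homo sapiens); on this read-out lower numbers stand for an effect already at smaller amounts and higher numbers for an effect only at larger amounts of compound. Compound 1 `CC#CC(CC(=O)O)c1ccc(OCc2ccn3cc(-c4cccc(C)c4)nc3c2)cc1` gives 1510 nM. Compound 2 `CC#CC(CC(=O)O)c1ccc(OCc2ccn3cc(-c4cc(F)ccc4F)nc3c2)cc1` gives 639 nM, and compound 3 `CC#CC(CC(=O)O)c1ccc(OCc2ccn3cc(-c4ccc(F)cc4F)nc3c2)cc1` gives 792 nM. On these numbers compound 3 stands second highest of the three, yet within the scatter of both others: a 1.2-fold higher number from compound 2 to compound 3 (0.09 log units; within the scatter), while a 1.9-fold lower number from compound 1 to compound 3 (0.28 log units; within the scatter). Among the measured compounds shown here, the only step beyond the scatter is a 2.4-fold lower number from compound 1 to compound 2 (0.37 log units; beyond the scatter). Compound 4 `CC#CC(CC(=O)O)c1ccc(OCc2ccn3cc(-c4ccccc4F)nc3c2)cc1` differs from compound 3 by hydrogen in place of fluoro on an aromatic carbon. For the measured compounds named here, no measured step removes a fluoro; the steps that swap or move fluoro groups are modest at most, so no change beyond the scatter is expected here. Compound 4 is therefore estimated at 900 nM, within 400 nM to 2000 nM. The step expected is a 1.1-fold higher number from compound 3 to compound 4 (0.06 log units; within the scatter).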

Compound 4, half-maximal effective concentration: 705 nM
The estimate for compound 4 lay 1.3-fold (0.11 log units) above the measured number; measured number inside the range.
By their numbers in this assay, from the lowest: compounds 2, 4, 3 and 1 (each within the scatter of the next, the first and the last beyond it).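

Losing a fluoro from either difluorophenyl compound leaves the number within the scatter (a 1.1-fold lower number from compound 3 to compound 4 (0.05 log units; within the scatter); a 1.1-fold higher number from compound 2 to compound 4 (0.04 log units; within the scatter)), so in these compounds the 2-fluorophenyl group reads the same as both difluorophenyl groups. The step from 3-methylphenyl to 2-fluorophenyl lies beyond the scatter but stays modest (a 2.1-fold lower number from compound 1 to compound 4 (0.33 log units; beyond the scatter)). Nothing at hand explains these numbers.

Whether the remaining fluoro matters stays open, since a plain phenyl ring does not appear among these compounds. From the compounds shown here alone, how an amine or a methoxy group at the same ring carbon would read is also open.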